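Swapping the amide-bound ring: pyridine to pyrimidine

The source may report more compounds than this note shows. Statements on the series, on what has been measured and on what is new or still open speak of the compounds shown alone.

Two compounds share a core in which a piperazine bearing a pyridin-2-yl group carries an acetamide arm. Compound 1 `CCc1cccc(NC(=O)CN2CCN(c3ccccn3)CC2)c1` reaches 26.2% in an assay on cells for agonist activity at D(4) dopamine receptor (Homo sapiens), read by luminescence and beta-arrestin recruitment, with a stated time of 90 min; a higher number here means a larger maximal response, a lower number a smaller maximal response. Compound 2 `O=C(CN1CCN(c2ccccn2)CC1)Nc1cccnc1` reaches 19% in this assay. Among the compounds with values here, the only change between them is the ring on the amide-type nitrogen, and the step of a number 7.2 percentage points lower from compound 1 to compound 2 (within the scatter) is within the scatter, so the two maximal responses cannot be told apart. Within the data shown here, compound 2 thus sits at the smaller of the two numbers, with compound 1 as its only neighbour and that gap within the scatter.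

Compound 3 `O=C(CN1CCN(c2ccccn2)CC1)Nc1cncnc1` differs from compound 2 by pyrimidin-5-yl in place of pyridin-3-yl on an amide-type nitrogen. Among the measured compounds shown here, the one measured step that bears on this place is the exchange of the ring on the amide-type nitrogen from compound 1 to compound 2, which stayed within the scatter. The present change is smaller still in kind, one aromatic ring of six heavy atoms for another. No step beyond the scatter is therefore expected in this assay, with the step of a number 2 percentage points lower from compound 2 to compound 3 (within the scatter) estimated as essentially flat. Compound 3 is expected to give about 17%, in the range 8% to 28%.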

Compound 3, largest response reached (Emax), in percent of the reference or control that the assay uses: "not active" (no number reported)
No number was reported for compound 3, and the estimate cannot be compared.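

Within the data shown here, compound 3 is recorded in this assay as "not active", without a number, so no step from compound 2 to compound 3 can be read. Nothing shown here offers an explanation for this result. The compounds shown leave open whether pyrimidin-5-yl in place of pyridin-3-yl truly lowers the maximal response.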